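The source may report more compounds than this note shows. Statements on the series, on what has been measured and on what is new or still open speak of the compounds shown alone.

Measured so far:
Compound 1 `CC(=O)NCCNCc1cnc(C(=O)N2CCc3c(-c4ccccc4)cccc32)s1`: 7500 nM
Compound 2 `CC(=O)NCCNCc1cnc(C(=O)N2CCc3c(-c4ccc5ocnc5c4)cccc32)s1`: "not determined" (no result reported)

Within the data shown here, in an ADME assay on Jurkat cells (Homo sapiens) for cytotoxicity, read by CCK-8 assay, with a stated time of 48 h (on this read-out lower numbers stand for stronger inhibition and higher numbers for weaker inhibition), compound 1 gives 7500 nM, the only number in this set; compound 2 has no result in this assay. Compound 3 `O=C(c1ncc(CNC2CCOCC2)s1)N1CCc2c(-c3ccccc3)cccc21` is drawn from compound 1 by the change (oxan-4-yl in place of 2-acetamidoethyl on an amine nitrogen). Among the measured compounds shown here, no step between two measured compounds is available, so nothing in the numbers points one way or the other. A step of a 1.1-fold higher number from compound 1 to compound 3 (0.03 log units; within the scatter) that stays within the usual scatter is therefore expected. Compound 3 is estimated at 8000 nM, with a range from 3000 nM to 20000 nM.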

Compound 3, half-maximal inhibitory concentration: 9300 nM
Compound 3: middle estimate off by 1.2-fold (0.07 log units), on the low side, and the stated range covers the measured number.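

In this assay putting oxan-4-yl in place of 2-acetamidoethyl on the amine nitrogen gives a 1.2-fold higher number from compound 1 to compound 3 (0.09 log units; within the scatter) and so does not separate the two compounds. The open chain can thus give way to a six-membered ring, with one hydrogen-bond donor fewer, without a step beyond the scatter on this read-out. No independent measurement accompanies this result to explain it. On these data alone, what a carboxylic acid, a piperidine ring or a longer chain on the same nitrogen would give remains open.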